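Changing the Benzyl Substituent Leaves Little Expected Shift

This account rests on a few compounds, and the source may have more. Where it says the series, first, only, none or still open, it means among the compounds named here.

In a functional assay on A2780 cells (Homo sapiens) for inhibition, read by MTT assay, with a stated time of 72 h (a lower number here means a stronger inhibitor, a higher number a weaker inhibitor), compound 1 `Cc1cccc(CN2CCc3ncn(COCc4ccccc4)c3/C(=C/c3ccccc3)C2=O)c1` gives 26300 nM and compound 2 `O=C1/C(=C\c2ccccc2)c2c(ncn2COCc2ccccc2)CCN1Cc1ccc(-c2ccccc2)cc1` gives 48300 nM within the scatter of it, so the two stand level. Compound 3 `COc1ccc(CN2CCc3ncn(COCc4ccccc4)c3/C(=C/c3ccccc3)C2=O)cc1` differs from compound 2 by methoxy in place of phenyl on an aromatic carbon with methoxy in place of phenyl on an aromatic carbon. Going by the values given here, the one measured step in this part of the molecule is a 1.8-fold higher number from compound 1 to compound 2 (0.26 log units; within the scatter) and it lies within the scatter. No step beyond the scatter is therefore expected in this assay and the estimated 1.5-fold lower number from compound 2 to compound 3 (0.18 log units; within the scatter) stays inside it. For compound 3 the expected value is 32000 nM with an estimated range from 13000 nM to 75000 nM in this read-out.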

Compound 3, half-maximal inhibitory concentration: 43100 nM
Compound 3: middle estimate off by 1.3-fold (0.13 log units), on the low side; the measured number falls inside the stated range.
By their numbers in this assay, from the lowest: compounds 1, 3 and 2 (each within the scatter of the next).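

In this assay, methoxy in place of phenyl gives a 1.1-fold lower number from compound 2 to compound 3 (0.05 log units; within the scatter), and 4-methoxyphenyl in place of 3-methylphenyl gives a 1.6-fold higher number from compound 1 to compound 3 (0.21 log units; within the scatter). Compounds 1, 2 and 3 therefore stand level, and at this place on the aromatic ring a methoxy of 2 heavy atoms with a hydrogen-bond acceptor reads the same as a phenyl of 6 heavy atoms with none. No available measurement offers a reason for this. From the compounds shown here alone, whether an amine or a carboxylic acid at this place would also stand level remains open, as does the effect of changes elsewhere on the shared core.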